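Acylating the ring nitrogen of compound 1

This account rests on a few compounds, and the source may have more. Where it says the series, first, only, none or still open, it means among the compounds named here.

In a functional assay on NCI-H1975 cells (Homo sapiens) for antiproliferative activity (on this read-out higher numbers stand for weaker inhibition and lower numbers for stronger inhibition), compound 1 `Cc1c2c(n3c1CCN(C)C[C@@H](C)[C@H](C)Nc1cc-3ccc1C(N)=O)CC(C)(C)CC2=O` gives 27 nM, and compound 3 `COCCC(=O)N1CCCc2c(C)c3c(n2-c2ccc(C(N)=O)c(c2)N[C@@H](C)[C@@H]1C)CC(C)(C)CC3=O` gives 37 nM, so the two stand level within the scatter. Compound 2 `Cc1c2c(n3c1CCCN(C(=O)CN)[C@@H](C)[C@H](C)Nc1cc-3ccc1C(N)=O)CC(C)(C)CC2=O` gives 380 nM, a clearly higher number than either.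

Compound 4 `COCCC(=O)N1CCc2c(C)c3c(n2-c2ccc(C(N)=O)c(c2)N[C@@H](C)[C@H](C)C1)CC(C)(C)CC3=O` differs from compound 1 by (2-methoxyethyl)carbonyl in place of methyl on an amine nitrogen in a ring.

Within the data shown here, no measured step isolates this change. The nearest evidence is a 10-fold lower number from compound 2 to compound 3 (1.01 log units; beyond the scatter), a large step with methoxymethyl in place of amino on a saturated chain carbon bound to a carbonyl carbon. It leaves compound 3 carrying the same (2-methoxyethyl)carbonyl at 37 nM, although its core is not that of compound 4. Exchanging methyl for this group therefore need not cost much in this assay. A small rise is expected, probably not beyond the scatter, and the estimated step is a 1.7-fold higher number from compound 1 to compound 4 (0.22 log units; within the scatter). For compound 4 the estimate is 45 nM, with an expected range of 15 nM to 140 nM.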

Compound 4, half-maximal inhibitory concentration: 31 nM
Compound 4: middle estimate off by 1.5-fold (0.16 log units), on the high side; the range from low to high includes it.
By their numbers in this assay, from the lowest: compounds 1, 4 and 3 (each within the scatter of the next); then compound 2.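

On the amine nitrogen in the ring, (2-methoxyethyl)carbonyl can now be read directly against methyl on the same core, and in this assay the exchange gives a 1.1-fold higher number from compound 1 to compound 4 (0.06 log units; within the scatter), a change that stays within the scatter. This position therefore accepts a chain of 6 heavy atoms with a carbonyl and 2 hydrogen-bond acceptors in place of a single methyl, with no resolved shift in antiproliferative read-out. Nothing available explains why the read-out holds at this position.

Open, as far as these compounds go, is whether a carboxylic acid at the end of the chain, or a longer chain, would be accepted on this nitrogen as well. Also open, from the compounds shown here alone, is whether the amino and methoxymethyl pair behind a 10-fold lower number from compound 2 to compound 3 (1.01 log units; beyond the scatter) would give a step of similar size on the core of compound 1.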